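Aryl-to-pyridyl swap on a piperazine amide series

A few compounds are considered here, and "the series" means these few. Any claim that something is new, unique, unknown or untested is made for them only; others in the source may bear on it.

Measured compounds:
compound 1, `O=C(COCc1ccccc1)N1CCN(c2ccccc2)CC1`, 7100 nM
compound 2, `O=C(COCc1ccccc1)N1CCN(c2ccccc2Cl)CC1`, 1100 nM
compound 3, `O=C(COCc1ccccc1)N1CCN(c2ccc(F)cc2)CC1`, 1100 nM

All three share one core and differ only in the aromatic ring on the ring nitrogen. In a functional assay on HEK293 cells for positive allosteric modulation of metabotropic glutamate receptor 5 (Homo sapiens), read by FLIPR and calcium flux (a lower number here means that less compound is needed, a higher number that more compound is needed for the effect), compound 1 gives 7100 nM, the highest of the three numbers. Adding a halogen helps: a 6.5-fold lower number from compound 1 to compound 2 (0.81 log units; beyond the scatter) and a 6.5-fold lower number from compound 1 to compound 3 (0.81 log units; beyond the scatter). Compound 3 stands level with compound 2, no change at the digits printed from compound 2 to compound 3 (within the scatter), so together these two give the lowest numbers here.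

Compound 4, `O=C(COCc1ccccc1)N1CCN(c2ccncc2)CC1`, has not yet been measured. The change from compound 3 is pyridin-4-yl in place of 4-fluorophenyl on an amine nitrogen in a ring. Going by the values given here, no measured step covers this swap. The closest guide is the step between compound 1 and compound 3: a bare aromatic ring gave a markedly higher number than a halogenated one, and the entering pyridine ring carries no halogen. A number near that of compound 1, or higher, is therefore expected, with wide uncertainty since no ring nitrogen has been tried. For compound 4 the estimate in this assay is 9000 nM, between 2500 nM and 35000 nM, corresponding to an 8.2-fold higher number from compound 3 to compound 4 (0.91 log units; beyond the scatter).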

Compound 4, half-maximal effective concentration: > 25000 nM
Compound 4: no number, only a limit; the forecaster's own chance of this, stated with the estimate: 25%; middle value at least 2.7-fold (0.44 log units) away from the limit.
By their numbers in this assay, from the lowest: compounds 2 and 3 (each within the scatter of the next); then compound 1. At a limit, above all of these: compound 4.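

In this assay compound 4 gives > 25000 nM, which is a limit of the assay and not a number: the limit of > 25000 nM in this assay, at which 1 of the 4 values shown sits.

Set against the two halogenated rings the swap is large, with an at least 22-fold higher number from compound 3 to compound 4 (1.35 log units; beyond the scatter) and an at least 22-fold higher number from compound 2 to compound 4 (1.35 log units; beyond the scatter), and even against the bare ring there is a clear rise, with an at least 3.5-fold higher number from compound 1 to compound 4 (0.54 log units; beyond the scatter). The earlier compounds shown here showed only what a halogen added to the aromatic ring on the amine nitrogen can do, whereas this result shows that changing an atom of that ring itself, with a ring nitrogen in place of carbon, moves the number the opposite way and further than the bare phenyl ring of compound 1 does.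

The compounds shown leave open whether pyridin-3-yl or pyridin-2-yl would behave like pyridin-4-yl, and whether a fluoro group on the pyridine ring would bring the number back down. They also leave open how groups other than halogens, such as a methoxy group or a nitrile on the phenyl ring, would compare with the chloro and fluoro compounds.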